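Removing the methyl from the methoxy group on the shared core

The compounds below may be only part of what the source reports. "The series", "measured", "known", "first", "only" and "open" are said of these compounds alone.

Of the compounds shown here, three built on one shared core have been tested in a functional assay on K562 cells (Homo sapiens) for cytotoxicity, read by sulforhodamine B assay, with a stated time of 48 h, tested at 0.01 uM; on this read-out higher numbers stand for a weaker effect at the one concentration tested and lower numbers for a stronger effect. Compound 1 `COc1cc(C)cc(-c2c(-c3ccnc(-c4ccc(C(C)=O)cc4)c3)cnn2CC#N)c1` gives 80%, compound 2 `Cc1cc(O)cc(-c2nn(CC#N)cc2-c2ccnc(-c3ccc(Oc4ccccc4)cc3)c2)c1` gives 44%, and compound 3 `COc1cc(C)cc(-c2nn(CC#N)cc2-c2ccnc(-c3ccc(N(C)C)cc3)c2)c1` gives 61%. Compound 3 therefore stands second highest of the three numbers: compound 2 sits lower by a gap that is beyond the usual scatter, and compound 1 sits higher by a gap that is also beyond it.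

Compound 4 `Cc1cc(O)cc(-c2nn(CC#N)cc2-c2ccnc(-c3ccc(N(C)C)cc3)c2)c1` is the next compound to be measured in this assay. It differs from compound 3 in one place only: hydrogen in place of methyl on an oxygen on an aromatic ring. Among the measured compounds shown here, no pair of measured compounds that differ in exactly this way is available, so the size of this step has not been seen directly. Compound 2, which carries the hydroxy, and compound 1, which carries the methoxy, also differ elsewhere, so their values only hint at a lower number.

Compound 4 is expected to give about 54%, within the range from 35% to 74%, which would mean an estimated step of a number 7 percentage points lower from compound 3 to compound 4 (within the scatter), a modest lowering that may still fall within the scatter.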

Compound 4, a percentage reported as activity, at one concentration (the size of the read-out at that concentration, not a potency): 101%
For compound 4 the middle estimate is 47 percentage points below the measured one, and the stated range ends below it.
By their numbers in this assay, from the lowest: compound 2; then compound 3; then compound 1; then compound 4.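

In this assay the change from methoxy to hydroxy, on an oxygen on an aromatic ring, gives a number 40 percentage points higher from compound 3 to compound 4 (beyond the scatter) with the dimethylamino group held constant. Removing a single methyl can therefore greatly weaken the effect on this core, and the hydroxy group does not bring a stronger effect in every compound that carries it. With the hydroxy group held constant, dimethylamino in place of phenoxy gives a number 57 percentage points higher from compound 2 to compound 4 (beyond the scatter) and the data shown offer no measurement that explains either step.

The compounds shown leave open whether the change from methoxy to hydroxy would have the same size alongside phenoxy. They also leave open how an ethoxy group or an amine would compare at this place on the 3-hydroxy-5-methylphenyl group.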